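Notes on compound 4: a second chlorophenyl arrangement

The source may hold more compounds than are shown below. What is called first, only, known or untested is meant among the compounds shown, and "the series" means these compounds.

Measured so far:
compound 1, `O=C1CSC(c2ccccc2Cl)N1CCN1CCCCC1`; in an ADME assay on Vero cells (Chlorocebus sabaeus) for cytotoxicity, read by neutral red uptake, tested at 394 ug/mL (a higher number here means a weaker effect of the compound at the concentration tested, a lower number a stronger effect), compound 1 gives 31%
compound 2, `COc1ccccc1C1SCC(=O)N1CCN1CCCCC1`; in this assay compound 2 gives 67%
compound 3, `O=C1CSC(c2ccccc2[N+](=O)[O-])N1CCN1CCCCC1`; in this assay compound 3 gives 100%

Compound 1 stands lowest of the three numbers, so it is the strongest of the three in this assay. The other two lie well away from it: a number 36 percentage points higher from compound 1 to compound 2 (beyond the scatter), a number 69 percentage points higher from compound 1 to compound 3 (beyond the scatter), and between those two a number 33 percentage points higher from compound 2 to compound 3 (beyond the scatter).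

Compound 4, `O=C1CSC(c2cccc(Cl)c2)N1CCN1CCCCC1`, differs from compound 1 by 3-chlorophenyl in place of 2-chlorophenyl on a saturated ring carbon. Among the measured compounds shown here, none of the measured steps bears on this change: each of them replaces chloro on an aromatic carbon by methoxy or nitro, whereas here the chlorine is kept and only the chlorophenyl group itself changes. For the measured compounds named here, no measured step therefore gives a size to expect, and the working expectation is a step within the scatter, with a wide range in either direction because the three compounds give no guide. Compound 4 is expected to give about 38%, between 15% and 75%. The expected step is a number 7 percentage points higher from compound 1 to compound 4 (within the scatter).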

Compound 4, a percentage reported as activity, at one concentration (the size of the read-out at that concentration, not a potency): 45%
Compound 4: the middle estimate sits 7 percentage points below what was measured, and the stated range covers the measured number.
By their numbers in this assay, from the lowest: compound 1; then compound 4; then compound 2; then compound 3.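

Moving from 2-chlorophenyl to 3-chlorophenyl on the saturated ring carbon in this assay gives a number 14 percentage points higher from compound 1 to compound 4 (beyond the scatter), a modest step with the same atoms on both sides. The earlier steps shown here all replaced chloro by methoxy or nitro on an aromatic carbon, so they showed only that the read-out follows the identity of the group; this step shows that it also follows where the chlorine sits on the phenyl, with the group itself kept. Nothing at hand accounts for this shift.

From the compounds shown here alone, it remains open whether methoxy or nitro would shift in the same direction if moved in the same way as the chlorine. Going by these compounds, how bromo, fluoro or a carboxylic acid would read in the place of the chlorine in 3-chlorophenyl also stays unknown.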